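The source may hold more compounds than are shown below. What is called first, only, known or untested is meant among the compounds shown, and "the series" means these compounds.

Series notes. For the measured compounds named here, compound 3 `C=CCN1CCC[C@H]1CNC(=O)c1cc(Br)cc(OC)c1OC` gives 210 nM in an assay on CHO cells for displacement of a labelled ligand from D(4) dopamine receptor (Homo sapiens) (a higher number here means a weaker inhibitor, a lower number a stronger inhibitor), the lowest of the three numbers so far. Compound 1 `C=CCN1CCC[C@H]1CNC(=O)c1cc(I)ccc1OC` gives 630 nM in this assay, and compound 2 `C=CCN1CCC[C@H]1CNC(=O)c1cc(CCCF)ccc1OC` gives 3000 nM. Compound 4 `C=CCN1CCC[C@H]1CNC(=O)c1cc(CCCF)cc(OC)c1OC` has not been measured; it differs from compound 3 by 3-fluoropropyl in place of bromo on an aromatic carbon. Going by the values given here, the one measured step that bears on this change is a 4.8-fold higher number from compound 1 to compound 2 (0.68 log units; beyond the scatter), in which a halogen on an aromatic carbon of the shared core was likewise replaced by 3-fluoropropyl. A step of comparable size and in the same direction is therefore expected here, meaning a higher number in this assay for compound 4. The expected step is a 4.3-fold higher number from compound 3 to compound 4 (0.63 log units; beyond the scatter). Compound 4 is estimated at 900 nM, within a range of 350 nM to 2500 nM.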

Compound 4, inhibition constant: 1300 nM
Estimate against measurement, compound 4: 1.4-fold (0.16 log units) below, and the stated range covers the measured number.
By their numbers in this assay, from the lowest: compound 3; then compound 1; then compound 4; then compound 2.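

In this assay the replacement of a halogen by 3-fluoropropyl again moves the number upward on the core carrying the second methoxy group, giving a 6.2-fold higher number from compound 3 to compound 4 (0.79 log units; beyond the scatter) in the same direction as the earlier step. With 3-fluoropropyl held constant, methoxy in place of hydrogen gives a 2.3-fold lower number from compound 2 to compound 4 (0.36 log units; beyond the scatter) and so offsets part of that loss. No measurement bearing on the reason for either step is available. Open, going by these compounds, is whether a longer chain such as 5-fluoropentyl, or a hydroxyl-ended propyl chain, would bring the number closer to that of compound 3 at this position. Also open, on these data alone, is whether the methoxy step holds with bromo in place of 3-fluoropropyl.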